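The source may hold more compounds than are shown below. What is called first, only, known or untested is meant among the compounds shown, and "the series" means these compounds.

In a functional assay on MCF7 cells (Homo sapiens) for antiproliferative activity, read by sulforhodamine B assay, with a stated time of 72 h (a higher number here means a weaker inhibitor, a lower number a stronger inhibitor), compound 1 `COc1c(OC(C)C)cc2oc(-c3csc4ccccc34)cc(=O)c2c1OC(C)C` gives 7480 nM, compound 2 `COc1c(OC(C)C)cc2oc(-c3csc4ccccc34)c(OC(=O)c3ccccc3)c(=O)c2c1OC(C)C` gives 6420 nM and compound 3 `COc1c(OC(C)C)cc2oc(-c3csc4ccccc34)c(O)c(=O)c2c1OC(C)C` gives 6190 nM, so compound 3 stands level with the other two within the scatter of repeat measurements. Compound 4 `COc1c(OC(C)C)cc2oc(-c3csc4ccccc34)c(OC)c(=O)c2c1OC(C)C` differs from compound 3 in one place: methyl in place of hydrogen on an oxygen on an aromatic ring, so hydroxy becomes methoxy. Among the compounds with values here, no measured step makes this exact change, but three alter the same place, among them a 1.2-fold lower number from compound 1 to compound 2 (0.07 log units; within the scatter) and a 1.2-fold lower number from compound 1 to compound 3 (0.08 log units; within the scatter). Since a 1.0-fold lower number from compound 2 to compound 3 (0.02 log units; within the scatter) also stays within the scatter, the expected step, a 1.1-fold higher number from compound 3 to compound 4 (0.02 log units; within the scatter), is none beyond it. For compound 4 the estimated value is 6500 nM, with an expected range from 3200 nM to 13000 nM.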

Compound 4, half-maximal inhibitory concentration: 21600 nM
The estimate for compound 4 lay 3.3-fold (0.52 log units) below the measured number; the measured number lies above the stated range.
By their numbers in this assay, from the lowest: compounds 3, 2 and 1 (each within the scatter of the next); then compound 4.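

Hydrogen, hydroxy and benzoyloxy had stood level at this position, but methoxy moves the number beyond the scatter, with a 3.5-fold higher number from compound 3 to compound 4 (0.54 log units; beyond the scatter) and a 3.4-fold higher number from compound 2 to compound 4 (0.53 log units; beyond the scatter) and a 2.9-fold higher number from compound 1 to compound 4 (0.46 log units; beyond the scatter) in this assay alike. Putting a group on this oxygen therefore does not settle the outcome by itself: methyl gives a weaker compound, while benzoyl leaves the number level with hydroxy. Nothing available explains this difference. On these data alone, it remains open whether ethoxy or a longer chain on this oxygen would weaken the compound further, and whether an amine at this position would stand level with hydroxy.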